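This account rests on a few compounds, and the source may have more. Where it says the series, first, only, none or still open, it means among the compounds named here.

In a functional assay on K562 cells (Homo sapiens) for cytotoxicity, read by MTT assay, with a stated time of 72 h (a higher number here means a weaker inhibitor, a lower number a stronger inhibitor), compound 1 `CCCC[C@H](CC)C[C@]1(CC)C=C(CC)/C(=C/C(=O)OC)O1` gives 5300 nM. Compound 2 `CCCCC(C)Cc1cc(CC)c(CC(=O)O)o1` gives > 100000 nM, which is a limit of the assay and not a number. Compound 3 `CCCCC(C)CC(O)(/C=C(/CC)[C@@H](O)CC(=O)OC)CC`, at 23800 nM, has the higher of the two actual numbers, and its gap to compound 1 lies beyond the usual scatter. Compound 4 `CCCCC(CC)CC(O)(/C=C(/CC)[C@@H](O)CC(=O)OC)CC` differs from compound 3 by one small change: methyl in place of hydrogen on a saturated chain carbon, four bonds along the chain from a double-bonded chain carbon and an oxygen on a saturated carbon. Here methyl replaces hydrogen on a saturated chain carbon, turning 1-methylpentyl into 1-ethylpentyl. For the measured compounds named here, no measured pair shows this change, so only a small shift within the scatter, with no firm direction, is expected in this assay. The expected step is a 1.2-fold lower number from compound 3 to compound 4 (0.08 log units; within the scatter). For compound 4 the estimated value is 20000 nM, with an expected range of 9000 nM to 45000 nM.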

Compound 4, half-maximal inhibitory concentration: 20000 nM
For compound 4 middle estimate and measured number coincide at the digits printed; measured number inside the range.
By their numbers in this assay, from the lowest: compound 1; then compounds 4 and 3 (each within the scatter of the next). At a limit, above all of these: compound 2.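

In this assay, turning 1-methylpentyl into 1-ethylpentyl gives a 1.2-fold lower number from compound 3 to compound 4 (0.08 log units; within the scatter), so adding a methyl at this saturated chain carbon leaves no readable effect on the number. This is the only step among the compounds shown that differs in one place, and it gives the first direct view of this position. No measurement shown accounts for this result. Going by these compounds, whether a longer chain, a hydroxyl or an amine at this carbon would also leave the number unmoved stays open. So does whether the same change would matter on the core of compound 1.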